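The source may report more compounds than this note shows. Statements on the series, on what has been measured and on what is new or still open speak of the compounds shown alone.

In a functional assay on NCI-H460 cells (Homo sapiens) for cytotoxicity, read by sulforhodamine B assay, with a stated time of 72 h (on this read-out lower numbers stand for stronger inhibition and higher numbers for weaker inhibition), compound 1 `COc1ccc(/C=C(/F)c2cc(OC)c(OC)c(OC)c2)cc1O` gives 1.1 nM. Within the data shown here, this is the lower of the two numbers available so far, and the gap is well beyond the scatter of repeated measurements: compound 2 `COc1ccc(/C=C\c2cc(OC)c(OC)c(OC)c2)cc1[N+](=O)[O-]` gives 128 nM. The next compound to consider, compound 3 `COc1ccc(/C=C(/F)c2cc(OC)c(OC)c(OC)c2)cc1N`, keeps the core of compound 1 and changes one group. It has amino in place of hydroxy on an aromatic carbon, ortho to a methoxy group and meta to a large group: amino in place of hydroxy on an aromatic carbon. Among the measured compounds shown here, no pair of measured compounds shows this swap on its own, so the data offer no direct guide to its size, and any forecast remains uncertain. Since compound 1 already reaches 1.1 nM, a small loss seems more likely than a further gain. The expected step of a 2.3-fold higher number from compound 1 to compound 3 (0.36 log units; beyond the scatter) is therefore a modest rise in the number, close to the edge of the scatter. For compound 3, the estimated value is 2.5 nM, with an expected range from 0.6 nM to 12 nM.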

Compound 3, half-maximal inhibitory concentration: 2.4 nM
The estimate for compound 3 lay 1.0-fold (0.02 log units) above the measured number; low and high end bracket the measured number.
By their numbers in this assay, from the lowest: compound 1; then compound 3; then compound 2.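

At this aromatic carbon, ortho to a methoxy group and meta to a large group, amino in place of hydroxy gives a 2.2-fold higher number from compound 1 to compound 3 (0.34 log units; beyond the scatter) in this assay, a modest change that still leaves compound 3 at 2.4 nM, so in this pair strong activity does not depend on keeping the hydroxy group. Hydroxy and amino match in their counts of heavy atoms, hydrogen-bond donors and acceptors, and neither carries a net charge, so these counts alone do not separate the two groups, even though the measured number moves beyond the usual scatter. Nothing measured here accounts for the size of this step.

Compound 2 carries a nitro group on this carbon but also differs from compound 1 and compound 3 elsewhere, so it cannot show the effect of that group alone. Still open, on these data alone, is how a methoxy group, a fluorine atom or a methylamino group would fare on this same carbon of the shared core, and whether amino in place of hydroxy would give a similar step on a core without the fluorine.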